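This account rests on a few compounds, and the source may have more. Where it says the series, first, only, none or still open, it means among the compounds named here.

Compound 1 `Cc1cn(CCCCCOc2ccc(Br)cc2)c(=O)[nH]c1=O` and compound 2 `CC(C)(C)c1ccc(OCCCCCn2ccc(=O)[nH]c2=O)cc1` were both tested for toxicity toward cultured human cells in an ADME assay on HEL cells (Homo sapiens) for cytotoxicity, read by microscopy; on this read-out higher numbers stand for lower toxicity in this test and lower numbers for higher toxicity in this test. In this assay compound 1 gives 100000 nM. In this assay compound 2 gives 100000 nM, level with compound 1 at the digits shown and within the usual scatter of this test. Compound 3 `Nc1ccc(OCCCCCn2ccc(=O)[nH]c2=O)cc1` differs from compound 2 by one change: amino in place of tert-butyl on an aromatic carbon. For the measured compounds named here, with two compounds at the same value and no measured step to lean on, the expected step from compound 2 to compound 3 is no change at the digits printed from compound 2 to compound 3 (within the scatter), none beyond the scatter. Compound 3 is therefore estimated at 100000 nM, within 50000 nM to 200000 nM.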

Compound 3, minimum cytotoxic concentration: > 100000 nM
Compound 3 gave a limit, no number; the forecaster's own chance of this, stated with the estimate: 60%; the middle value sits exactly at the limit.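

In this assay, putting amino in place of tert-butyl gives a number no lower from compound 2 to compound 3 (the limit leaves the size open). The reading > 100000 nM for compound 3 is a limit of the assay, not a number. This place on the aromatic ring therefore takes a single nitrogen group carrying a hydrogen-bond donor and acceptor, instead of four carbons, with no lower number appearing: the limit of > 100000 nM in this assay, at which 1 of the 3 values shown sits.

As far as these compounds go, how far the number rises stays unknown. From the compounds shown here alone, whether a carboxylic acid at this place, or a longer chain in the linker, would bring the number down also remains open.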